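Swapping the halogen and its place on the phenyl ring

The compounds below may be only part of what the source reports. "The series", "measured", "known", "first", "only" and "open" are said of these compounds alone.

Among the compounds with values here, compound 2 `CCc1nn(C)c2c1C(c1cccc(F)c1)=NCC(=O)N2` gives 20 mg/kg in a functional assay on the whole organism (strain Holtzman) with Rattus norvegicus as the target (a lower number here means that less compound is needed, a higher number that more compound is needed for the effect), the higher of the two numbers measured so far; compound 1 `CCc1nn(C)c2c1C(c1ccccc1)=NCC(=O)N2` gives 2.5 mg/kg. Within the data shown here, the one measured step, an 8.0-fold higher number from compound 1 to compound 2 (0.90 log units; beyond the scatter), shows that a fluoro on that ring raised the dose needed. Compound 3 `CCc1nn(C)c2c1C(c1ccccc1Cl)=NCC(=O)N2` carries 2-chlorophenyl in place of 3-fluorophenyl on a carbon with a double bond to nitrogen. Among the measured compounds shown here, no measured step covers a chloro or this ring position, so the direction is open; compound 3 is expected to land between its two neighbours, at 5 mg/kg (range 1.5 mg/kg to 25 mg/kg), a step of a 4.0-fold lower number from compound 2 to compound 3 (0.60 log units; beyond the scatter).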

Compound 3, minimum effective dose: 2.5 mg/kg
For compound 3 the middle estimate is 2.0-fold (0.30 log units) above the measured one, and the stated range covers the measured number.
By their numbers in this assay, from the lowest: compounds 1 and 3 (each within the scatter of the next); then compound 2.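

So a substituent on this phenyl ring does not always raise the dose: in this assay, the 2-chlorophenyl group gives no change at the digits printed from compound 1 to compound 3 (within the scatter). Moving from 3-fluorophenyl to 2-chlorophenyl gives an 8.0-fold lower number from compound 2 to compound 3 (0.90 log units; beyond the scatter), so the higher dose seen with the fluoro does not extend to every halogen-bearing phenyl ring. No evidence is available to explain this difference. The halogen and its ring place changed together here, so 2-fluorophenyl and 3-chlorophenyl would be needed to separate the two. From the compounds shown here alone, how a methoxy or an amine on this ring would behave also remains open.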